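The source may report more compounds than this note shows. Statements on the series, on what has been measured and on what is new or still open speak of the compounds shown alone.

The two compounds measured so far, with their values in a functional assay on T47D cells (Homo sapiens) for cytotoxicity, read by MTT assay, with a stated time of 2 days; on this read-out higher numbers stand for weaker inhibition and lower numbers for stronger inhibition:

compound 1, `Cc1ccc2c(=O)[nH]c(-c3ccccc3N(C)C)nc2c1`: 4430 nM
compound 2, `Cc1ccc2c(=O)[nH]c(-c3cccc(OC(F)(F)F)c3)nc2c1`: > 50000 nM

Both share the same core and differ only in the substituted phenyl attached to it. Compound 1 gives a measured number. For compound 2 the result is not a number but a limit of the assay, (the limit of > 50000 nM in this assay, at which 1 of the 2 values shown sits), so compound 2 sits at the weak end of what this assay can report. Of the two values shown, only compound 1 falls inside the measurable range.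

Compound 3, `Cc1ccc2c(=O)[nH]c(-c3cccc(F)c3)nc2c1`, is the next step from compound 2: fluoro in place of trifluoromethoxy on an aromatic carbon. Going by the values given here, no step between two measured compounds is available here to calibrate this kind of change, so the expectation rests on the two values alone. The change from compound 2 to compound 3 is expected to give a modest gain in inhibition in this assay, an at least 1.6-fold lower number from compound 2 to compound 3 (0.22 log units; that floor lies within the scatter), though compound 3 may well still come back as a limit. Compound 3 is estimated at 30000 nM, with a range from 8000 nM to 100000 nM.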

Compound 3, half-maximal inhibitory concentration: > 50000 nM
Compound 3 gave a limit, no number; the forecaster's own chance of this, stated with the estimate: 45%; middle value at least 1.6-fold (0.22 log units) away from the limit.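

Compound 2 and compound 3 both come back in this assay as a limit rather than a number, so the size of the step between them cannot be read: the limit of > 50000 nM in this assay, at which 2 of the 3 values shown sit. As far as these compounds go, what stays open is whether fluoro in place of trifluoromethoxy changes inhibition at all in this assay, and if so, by how much and in which direction.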